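The source may hold more compounds than are shown below. What is called first, only, known or untested is meant among the compounds shown, and "the series" means these compounds.

Series notes. Compound 1 `Cc1n[nH]c(C(=O)O)c1Cc1cccc(-c2ccc(C#N)cc2)c1`, compound 2 `Cc1n[nH]c(C(=O)O)c1Cc1cccc(-c2ccccc2F)c1` and compound 3 `Cc1n[nH]c(C(=O)O)c1Cc1cccc(C(N)=O)c1` share one core. In an assay on isolated protein for inhibition of 2-Hydroxyacid oxidase 2 (Homo sapiens), tested at 1 uM (a lower number here means a weaker effect, a higher number a stronger effect of the compound at the concentration tested), compound 1 gives 13%, compound 2 gives 5% and compound 3 gives 8%. Compound 3 sits within the usual scatter of both others: a number 5 percentage points lower from compound 1 to compound 3 (within the scatter) and a number 3 percentage points higher from compound 2 to compound 3 (within the scatter), as does a number 8 percentage points lower from compound 1 to compound 2 (within the scatter). Compound 4 `Cc1n[nH]c(C(=O)O)c1Cc1cccc(C(F)(F)F)c1` differs from compound 3 at the aromatic carbon that all three measured steps vary: trifluoromethyl in place of carbamoyl on an aromatic carbon. For the measured compounds named here, no measured step places trifluoromethyl there, so the two steps into compound 3 are the only guide, and both stayed within the scatter. In this assay the expected step is no change at the digits printed from compound 3 to compound 4 (within the scatter), none beyond the scatter. Compound 4 is therefore estimated at 8%, with a range from 0% to 20%.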

Compound 4, a percentage reported as inhibition, at one concentration (the size of the read-out at that concentration, not a potency): 5%
For compound 4 the middle estimate is 3 percentage points above the measured one, and the stated range covers the measured number.
By their numbers in this assay, from the lowest: compounds 2, 4, 3 and 1 (each within the scatter of the next).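

In this assay the change from carbamoyl to trifluoromethyl gives a number 3 percentage points lower from compound 3 to compound 4 (within the scatter) and so does not separate a group with a hydrogen-bond donor and acceptor from one with neither. The other new steps give no change at the digits printed from compound 2 to compound 4 (within the scatter) and a number 8 percentage points lower from compound 1 to compound 4 (within the scatter) and leave this aromatic carbon with four groups, two with a ring and two without, none set apart beyond the scatter. No evidence on hand bears on this flat read-out.

From the compounds shown here alone, whether an amine or a longer chain at this carbon would give a step beyond the scatter stays open.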